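The compounds below may be only part of what the source reports. "The series", "measured", "known", "first", "only" and "open" are said of these compounds alone.

Among the measured compounds shown here, in a functional assay on HT-29 cells (Homo sapiens) for antiproliferative activity, read by MTT assay, with a stated time of 72 h (on this read-out lower numbers stand for stronger inhibition and higher numbers for weaker inhibition), compound 1 `Cc1ccc(N2CCN(C(=S)SCc3ccc4nc(N)nc(N)c4c3)CC2)cc1` gives 3020 nM and compound 2 `Cc1ccccc1N1CCN(C(=S)SCc2ccc3nc(N)nc(N)c3c2)CC1` gives 2950 nM, so compound 2 stands level with the only other measured compound. Compound 3 `Nc1nc(N)c2cc(CSC(=S)N3CCN(c4ccc(Cl)cc4)CC3)ccc2n1` carries 4-chlorophenyl in place of 2-methylphenyl on an amine nitrogen in a ring. For the measured compounds named here, the only measured step that bears on this group is a 1.0-fold lower number from compound 1 to compound 2 (0.01 log units; within the scatter), which stays within the scatter and involves no chlorine, so no change beyond the scatter is expected in this assay. The expected step is a 1.2-fold lower number from compound 2 to compound 3 (0.07 log units; within the scatter). The estimated value for compound 3 is 2500 nM, with an expected range of 900 nM to 7000 nM.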

Compound 3, half-maximal inhibitory concentration: 7480 nM
Compound 3: the middle estimate sits 3.0-fold (0.48 log units) below what was measured; the whole stated range lies below it.
By their numbers in this assay, from the lowest: compounds 2 and 1 (each within the scatter of the next); then compound 3.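

In this assay the group on the amine nitrogen in a ring can move the read-out beyond the scatter, which the exchange of 4-methylphenyl and 2-methylphenyl did not show. Chloro in place of methyl on an aromatic carbon gives a 2.5-fold higher number from compound 1 to compound 3 (0.39 log units; beyond the scatter) and 4-chlorophenyl in place of 2-methylphenyl gives a 2.5-fold higher number from compound 2 to compound 3 (0.40 log units; beyond the scatter), so both steps point to modestly weaker inhibition. Nothing measured here accounts for these steps. As far as these compounds go, it remains open how a methoxy, a fluoro or an amine on the same phenyl ring would compare, and whether 2-chlorophenyl would read like compound 3 .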